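A few compounds are considered here, and "the series" means these few. Any claim that something is new, unique, unknown or untested is made for them only; others in the source may bear on it.

Compound 2 `COC(=O)c1c(C(F)(F)F)[n+]([O-])c2ccccc2[n+]1[O-]` carries the shared core without any extra methyl. In an ADME assay on J774 cells (Mus musculus) for cytotoxicity, read by MTT assay, with a stated time of 48 h (a higher number here means a weaker inhibitor, a lower number a stronger inhibitor), compound 2 gives 19000 nM. Compound 1 `COC(=O)c1c(C(F)(F)F)[n+]([O-])c2ccc(C)cc2[n+]1[O-]` differs from it by methyl in place of hydrogen on an aromatic carbon, a step of a 4.8-fold lower number from compound 2 to compound 1 (0.68 log units; beyond the scatter), and compound 1 gives 4000 nM. Compound 3 `CCOC(=O)c1c(C(F)(F)F)[n+]([O-])c2ccccc2[n+]1[O-]` instead differs from compound 2 by methyl in place of hydrogen on a saturated chain carbon bound to an oxygen next to a carbonyl group, which is also how the core of compound 4 differs from the core of compound 1; that step was a 4.8-fold lower number from compound 2 to compound 3 (0.68 log units; beyond the scatter), and compound 3 gives 4000 nM, level with compound 1 within the scatter. Compound 4 `CCOC(=O)c1c(C(F)(F)F)[n+]([O-])c2ccc(C)cc2[n+]1[O-]` has not yet been measured in this assay. It differs from compound 3 by methyl in place of hydrogen on an aromatic carbon. This is the same change already seen from compound 2 to compound 1, at a place described in identical terms, now made on the core of compound 3 rather than that of compound 2. The step is expected to be a 4.0-fold lower number from compound 3 to compound 4 (0.60 log units; beyond the scatter), because the same change once gave a 4.8-fold lower number from compound 2 to compound 1 (0.68 log units; beyond the scatter), with some room for a smaller gain on a core that already sits low. Compound 4 is therefore estimated at 1000 nM, most likely between 400 nM and 2500 nM.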

Compound 4, half-maximal inhibitory concentration: 7000 nM
For compound 4 the middle estimate is 7.0-fold (0.85 log units) below the measured one, and the stated range ends below it.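

In this assay, methyl in place of hydrogen on an aromatic carbon gives a 1.8-fold higher number from compound 3 to compound 4 (0.24 log units; within the scatter), so the clear step seen on the core of compound 2 does not carry over to the core of compound 3: the same change on two cores in this assay, a 4.8-fold lower number (0.68 log units; beyond the scatter) from compound 2 to compound 1 and a 1.8-fold higher number (0.24 log units; within the scatter) from compound 3 to compound 4, 8.3-fold (0.92 log units) apart, beyond the scatter of two such steps. Methyl in place of hydrogen on a saturated chain carbon bound to an oxygen next to a carbonyl group behaves the same way, giving a 1.8-fold higher number from compound 1 to compound 4 (0.24 log units; within the scatter) on the core of compound 1: the same change on two cores in this assay, a 4.8-fold lower number (0.68 log units; beyond the scatter) from compound 2 to compound 3 and a 1.8-fold higher number (0.24 log units; within the scatter) from compound 1 to compound 4, 8.3-fold (0.92 log units) apart, beyond the scatter of two such steps. Going by these compounds alone, neither step can therefore be carried from one core to another here as a fixed amount, though each change has been seen on only two cores, and these numbers do not show why the steps differ.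

The compounds shown leave open how a different group would behave when combined with either methyl, such as a chlorine atom on the same aromatic carbon or a longer chain in place of the ethyl chain. They also leave open whether the same mismatch between steps would appear on other cores in this series.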